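The source may hold more compounds than are shown below. What is called first, only, known or untested is meant among the compounds shown, and "the series" means these compounds.

Measured in an in vitro functional assay on HEK285-7 cells for antagonist activity at prostaglandin D2 receptor 2 (Homo sapiens), read by BRET and beta-arrestin recruitment; on this read-out higher numbers stand for weaker inhibition and lower numbers for stronger inhibition:
compound 1 `O=C(O)Cc1sc(C(c2ccc(F)cc2)c2ccc(F)cc2)nc1-c1ccc(Cl)cc1`: 180 nM
compound 2 `O=C(O)Cc1sc(C(c2ccc(F)cc2)c2ccc(F)cc2)nc1-c1ccccc1`: 240 nM
compound 3 `Cc1cc(-c2nc(C(c3ccc(F)cc3)c3ccc(F)cc3)sc2CC(=O)O)ccn1`: 53 nM

Compound 3 holds the lowest number of the three: a 3.4-fold lower number from compound 1 to compound 3 (0.53 log units; beyond the scatter) and a 4.5-fold lower number from compound 2 to compound 3 (0.66 log units; beyond the scatter), both modest and beyond the scatter, whereas a 1.3-fold higher number from compound 1 to compound 2 (0.12 log units; within the scatter). Compound 4 `Nc1cc(-c2nc(C(c3ccc(F)cc3)c3ccc(F)cc3)sc2CC(=O)O)cc(F)n1` keeps the core of compound 3 and differs in one place: 2-amino-6-fluoropyridin-4-yl in place of 2-methylpyridin-4-yl on an aromatic carbon. Among the measured compounds shown here, no measured step bears on the amino or the fluorine on this group; the two steps into compound 3 show only that the 2-methylpyridin-4-yl group gave a lower number than phenyl or 4-chlorophenyl. Compound 4 keeps a group of the same kind, so no step beyond the scatter is expected in this assay, though the uncertainty is wide. The estimate for compound 4 is 70 nM (range 25 nM to 250 nM), meaning an expected 1.3-fold higher number from compound 3 to compound 4 (0.12 log units; within the scatter).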

Compound 4, half-maximal inhibitory concentration: 1400 nM
Compound 4: middle estimate off by 20-fold (1.30 log units), on the low side; measured number above the stated range.
By their numbers in this assay, from the lowest: compound 3; then compounds 1 and 2 (each within the scatter of the next); then compound 4.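

In this assay, this position does not treat all six-membered aromatic rings with 1 hetero atom alike: 2-amino-6-fluoropyridin-4-yl in place of 2-methylpyridin-4-yl gives a 26-fold higher number from compound 3 to compound 4 (1.42 log units; beyond the scatter). The new group also ranks behind phenyl and 4-chlorophenyl, with a 5.8-fold higher number from compound 2 to compound 4 (0.77 log units; beyond the scatter) and a 7.8-fold higher number from compound 1 to compound 4 (0.89 log units; beyond the scatter), so the ring nitrogen alone does not secure the lower number seen for compound 3. No measurement at hand accounts for this large step.

The compounds shown do not separate the contribution of the amino group from that of the fluorine. 2-Aminopyridin-4-yl and 2-fluoropyridin-4-yl would each carry one of them alone at this position.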